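Branching the Ester Chain in a Retinoid-Like Series

The source may report more compounds than this note shows. Statements on the series, on what has been measured and on what is new or still open speak of the compounds shown alone.

Of the compounds shown here, three have so far been tested in a functional assay on K562 cells (Homo sapiens) for inhibition, read by MTT assay, with a stated time of 48 h; a lower number here means a stronger inhibitor, a higher number a weaker inhibitor. Compound 1 `Cc1cc2c(cc1C(=O)c1ccc(C(=O)OCCCCOC(=O)c3ccc(C(=O)Nc4ccc5c(c4)C(C)(C)CCC5(C)C)cc3)cc1)C(C)(C)CCC2(C)C` gives 84100 nM in this assay. Compound 2 `C=C(c1ccc(C(=O)NCCCCCCNC(=O)c2ccc(C(=O)Nc3ccc4c(c3)C(C)(C)CCC4(C)C)cc2)cc1)c1cc2c(cc1C)C(C)(C)CCC2(C)C`, which joins its two ends through an amide-linked chain rather than an ester-linked one, gives 294000 nM. Compound 3 `CCCC(=O)OCCCCOC(=O)c1ccc(C(=O)Nc2ccc3c(c2)C(C)(C)CCC3(C)C)cc1`, the smallest of the three, carries only a short ester tail on the shared core and gives 92600 nM.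

On these numbers compound 3 stands in the middle: its value and that of compound 1 lie within the usual scatter of each other, so the two cannot be told apart, while compound 2 gives a clearly higher number and is therefore the weaker inhibitor of the pair.

Compound 4 `CCCC(CCC)C(=O)OCCCCOC(=O)c1ccc(C(=O)Nc2ccc3c(c2)C(C)(C)CCC3(C)C)cc1` is the next step. It differs from compound 3 in one place: 1-propylbutyl in place of propyl on a carbonyl carbon. The change adds carbon to the tail of the ester while leaving the rest of the molecule untouched. Within the data shown here, no measured pair in this set shows what such a lengthening does, so the expectation rests on the closeness of compound 1 and compound 3 alone, both of which sit near the same weak level despite very different tails. The expected step from compound 3 to compound 4 is therefore small, a 1.1-fold lower number from compound 3 to compound 4 (0.04 log units; within the scatter), with no direction beyond the scatter. Compound 4 is estimated to give 85000 nM in this assay, with a likely range from 30000 nM to 250000 nM.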

Compound 4, half-maximal inhibitory concentration: > 1000000 nM
Compound 4: a limit, no number; the forecaster's own chance of this, stated with the estimate: 20%; at least 11-fold (1.07 log units) between middle value and limit.
By their numbers in this assay, from the lowest: compounds 1 and 3 (each within the scatter of the next); then compound 2. At a limit, above all of these: compound 4.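

Among these compounds, replacing propyl with 1-propylbutyl on a carbonyl carbon gives the first single change in this set that can be read, and it is a large one in this assay: an at least 10-fold higher number from compound 3 to compound 4 (1.03 log units; beyond the scatter). Compound 4 gives > 1000000 nM, which is a limit of the assay and not a number. The result shows that this carbonyl carbon is not a place where the group can be altered freely, something the earlier compounds could not show with no single-place change among them, and compound 4 alone stands at that limit: the limit of > 1000000 nM in this assay, at which 1 of the 4 values shown sits.

The compounds shown leave open whether the step follows from the added carbon or from the branching of the 1-propylbutyl group, as this one change brings both at once, and a longer unbranched chain on the same carbonyl carbon would tell the two apart. They also leave open how a tail ending in an amine or a carboxylic acid would read in this assay, and whether any group at this place can give a lower number than propyl.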